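Ureido in place of sulfamoyl: expected shift in the series

This account rests on a few compounds, and the source may have more. Where it says the series, first, only, none or still open, it means among the compounds named here.

Of the compounds shown here, two of the shared core have been measured in an assay on microsomes from liver (strain Wistar) for inhibition of acyl-CoA desaturase 1 (Rattus norvegicus), read by HPLC, with stated times of 1 h and 60 min; on this read-out higher numbers stand for weaker inhibition and lower numbers for stronger inhibition. Compound 1 `NC(=O)c1cnc(N2CCC(Oc3ccccc3C(F)(F)F)CC2)s1` gives 3 nM. Within the data shown here, compound 2 `NS(=O)(=O)c1cnc(N2CCC(Oc3ccccc3C(F)(F)F)CC2)s1` gives 41 nM, and among the two numbers compound 2 stands highest; the only measured step, a 14-fold higher number from compound 1 to compound 2 (1.14 log units; beyond the scatter), is large and beyond the scatter.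

Compound 3 `NC(=O)Nc1cnc(N2CCC(Oc3ccccc3C(F)(F)F)CC2)s1` is not yet measured. It differs from compound 2 by ureido in place of sulfamoyl on an aromatic carbon. Among the measured compounds shown here, the one measured step that bears on this change is a 14-fold higher number from compound 1 to compound 2 (1.14 log units; beyond the scatter): replacing carbamoyl with sulfamoyl raised the number sharply. The ureido group, like carbamoyl and unlike sulfamoyl, brings 1 double bond outside aromatic rings and 1 oxygen, so the present change goes part of the way back toward compound 1. For the measured compounds named here, compound 3 is therefore expected to give a lower number than compound 2, a step estimated at a 4.1-fold lower number from compound 2 to compound 3 (0.61 log units; beyond the scatter), though not necessarily reaching compound 1, since no measured pair contains ureido itself. The estimate for compound 3 in this assay is 10 nM, with a range of 3 nM to 40 nM.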

Compound 3, half-maximal inhibitory concentration: 150 nM
Compound 3: the middle estimate sits 15-fold (1.18 log units) below what was measured, outside the stated range (above it).
By their numbers in this assay, from the lowest: compound 1; then compound 2; then compound 3.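

In this assay, on the aromatic carbon next to the ring sulfur, ureido in place of carbamoyl brings a 50-fold higher number from compound 1 to compound 3 (1.70 log units; beyond the scatter) and ureido in place of sulfamoyl brings a 3.7-fold higher number from compound 2 to compound 3 (0.56 log units; beyond the scatter) among the three compounds at this position. A carbonyl shared with carbamoyl therefore does not carry over the low number, and ureido, with the same count of heavy atoms as sulfamoyl, ends highest of the three, so the span at this position is wider than a 14-fold higher number from compound 1 to compound 2 (1.14 log units; beyond the scatter) alone indicated. Nothing available here accounts for the rise from either group to ureido.

Still open, from the compounds shown here alone, is whether an acetamido group, which keeps the nitrogen on the aromatic carbon but loses the terminal amine of ureido, follows compound 3, and whether a methyl amide or a nitrile stays nearer compound 1. The three compounds also leave open whether this order of carbamoyl, sulfamoyl and ureido holds when the trifluoromethyl group on the shared core gives way to a chlorine or a methoxy group.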